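Cyano to methoxycarbonyl: the next step in the series

The source may report more compounds than this note shows. Statements on the series, on what has been measured and on what is new or still open speak of the compounds shown alone.

In a functional assay on MKN-45 cells (Homo sapiens) for antiproliferative activity (a lower number here means a stronger inhibitor, a higher number a weaker inhibitor), compound 1 (`COc1ccc(Nc2cccc3c2N(S(=O)(=O)c2ccc(OC)cc2)CC3)cc1`) gives 487 nM and compound 2 (`COc1ccc(S(=O)(=O)N2CCc3cccc(Nc4ccc(C#N)cc4)c32)cc1`) gives 92 nM, the lower of the two numbers. Compound 3 (`COC(=O)c1ccc(Nc2cccc3c2N(S(=O)(=O)c2ccc(OC)cc2)CC3)cc1`) has methoxycarbonyl in place of cyano on an aromatic carbon, para to a large group: methoxycarbonyl in place of cyano on an aromatic carbon. Among the measured compounds shown here, only one measured step bears on this place: a 5.3-fold lower number from compound 1 to compound 2 (0.72 log units; beyond the scatter), with cyano in place of methoxy. For the measured compounds named here, no methoxycarbonyl compound has been measured, so the evidence is thin. In this assay, the expected change is a 2.2-fold higher number from compound 2 to compound 3 (0.34 log units; beyond the scatter), probably smaller than that measured step and toward a higher number. Compound 3 is estimated at 200 nM, within a range of 70 nM to 550 nM.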

Compound 3, half-maximal inhibitory concentration: 487 nM
Beside the measured number, compound 3's estimate is 2.4-fold (0.39 log units) below it, within the range that was stated.
By their numbers in this assay, from the lowest: compound 2; then compounds 1 and 3 (each within the scatter of the next).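

In this assay methoxycarbonyl gives back the whole gain that cyano brought at this place, with a 5.3-fold higher number from compound 2 to compound 3 (0.72 log units; beyond the scatter) and with no change at the digits printed from compound 1 to compound 3 (within the scatter) in the comparison against methoxy. Among the three groups on this aromatic carbon, para to a large group, only cyano stands apart, and methoxycarbonyl and methoxy cannot be told apart. No evidence bears on the reason for this result.

Open, as far as these compounds go, is whether a carboxylic acid, a primary amide or a fluorine at this place would read like cyano or like methoxycarbonyl. Also open, from the compounds shown here alone, is whether the cyano gain holds with a different group on the sulfonyl of the shared core.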